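The source may hold more compounds than are shown below. What is called first, only, known or untested is meant among the compounds shown, and "the series" means these compounds.

Measured so far in a functional assay on SW480 cells (Homo sapiens) for cytotoxicity, read by MTT assay, with a stated time of 48 h; on this read-out higher numbers stand for weaker inhibition and lower numbers for stronger inhibition:
compound 1, `Cc1cccc(Cn2cc(COc3ccc4c(=O)ccoc4c3)nn2)c1`: 11700 nM
compound 2, `O=c1ccoc2cc(OCc3cn(Cc4ccc([N+](=O)[O-])cc4)nn3)ccc12`: 19300 nM
compound 3, `O=c1ccoc2cc(OCc3cn(Cc4cccc(Br)c4)nn3)ccc12`: a limit of the assay, > 100000 nM

Compound 2 holds the highest of the two numbers; compound 1 lies a 1.6-fold higher number from compound 1 to compound 2 (0.22 log units; within the scatter) from it, a gap within the scatter. Compound 3 gives only a limit, (the limit of > 100000 nM in this assay, at which 1 of the 3 values shown sits). Compound 4, `Cc1ccccc1Cn1cc(COc2ccc3c(=O)ccoc3c2)nn1`, is not yet measured; it differs from compound 2 by 2-methylphenyl in place of 4-nitrophenyl on a saturated chain carbon bound to an aromatic nitrogen. The step that bears on it is the one between a methylphenyl and the nitrophenyl, a 1.6-fold higher number from compound 1 to compound 2 (0.22 log units; within the scatter), within the scatter; the step of an at least 5.1-fold higher number from compound 2 to compound 3 (0.71 log units; beyond the scatter) involves bromo and is less relevant. A return to a methylphenyl is therefore expected to change the number little beyond the scatter: compound 4 is estimated at 12000 nM (range 5000 nM to 35000 nM), a step of a 1.6-fold lower number from compound 2 to compound 4 (0.21 log units; within the scatter).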

Compound 4, half-maximal inhibitory concentration: > 100000 nM
Compound 4 ended at the assay's limit (the forecaster's own chance of this, stated with the estimate: 10%); at least 8.3-fold (0.92 log units) between middle value and limit.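

In this assay, going by these compounds alone, the place of the methyl on the ring counts at this position, more than the earlier compounds suggested: the 2-methylphenyl and 3-methylphenyl groups are not interchangeable, an at least 8.5-fold higher number from compound 1 to compound 4 (0.93 log units; beyond the scatter). The 4-nitrophenyl group also keeps a measurable number where 2-methylphenyl does not, an at least 5.1-fold higher number from compound 2 to compound 4 (0.71 log units; beyond the scatter). Compound 3 and compound 4 both give a limit and not a number, so the step between them cannot be read: the limit of > 100000 nM in this assay, at which 2 of the 4 values shown sit.

Open, on these data alone, is whether a 4-methylphenyl, an aminophenyl or a longer chain at this place would keep a measurable number. As far as these compounds go, how far compound 3 and compound 4 lie beyond the limit also remains open.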